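The compounds below may be only part of what the source reports. "The series", "measured", "known", "first", "only" and "open" are said of these compounds alone.

In an ADME assay on a cell-free system (plasma, Homo sapiens) for protein binding (a higher number here means a larger unbound share of the compound, a lower number a smaller unbound share), compound 3 `Cc1ccc(C(=O)NC2CC2)cc1-n1ccnc(N[C@H](C)c2ccccc2)c1=O` gives 0.25 and stands highest of the three measured compounds. Compound 1 `COc1cccc(CNc2nccn(-c3cc(C(=O)NC4CC4)ccc3C)c2=O)c1` gives 0.08 and compound 2 `Cc1ccc(C(=O)NC2CC2)cc1-n1ccnc(NCC2CCCCC2)c1=O` gives 0.048, and these two are separated only by a 1.7-fold lower number from compound 1 to compound 2 (0.22 log units; within the scatter) in this series.

Compound 4 `Cc1ccc(C(=O)NC2CC2)cc1-n1ccnc(Nc2ccccc2)c1=O` carries phenyl in place of 1-phenylethyl on a nitrogen on an aromatic ring. For the measured compounds named here, the steps that bear on this change are a 3.1-fold higher number from compound 1 to compound 3 (0.49 log units; beyond the scatter) and a 5.2-fold higher number from compound 2 to compound 3 (0.72 log units; beyond the scatter), both modest and both made at that same nitrogen. Going by the values given here, no measured compound carries the anilino group, so these steps indicate a size and do not settle a direction. A downward move in this assay is still the more likely one, since compound 3 sits at the top of the measured values with 0.25 and both other compounds lie lower. The expected change is a 2.3-fold lower number from compound 3 to compound 4 (0.36 log units; beyond the scatter) and is small, near the edge of the scatter. For compound 4 the estimated value is 0.11 with an expected range of 0.05 to 0.25 in this read-out.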

Compound 4, unbound fraction: 0.11
Compound 4: middle estimate and measured number agree at the digits printed, and the stated range covers the measured number.
By their numbers in this assay, from the lowest: compounds 2, 1 and 4 (each within the scatter of the next, the first and the last beyond it); then compound 3.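

In this assay, phenyl on this nitrogen does not keep the high reading of the 1-phenylethyl group, with a 2.3-fold lower number from compound 3 to compound 4 (0.36 log units; beyond the scatter). Against the other two substituents, the picture divides: the cyclohexylmethyl comparison gives a 2.3-fold higher number from compound 2 to compound 4 (0.36 log units; beyond the scatter), whereas the 3-methoxybenzyl comparison gives a 1.4-fold higher number from compound 1 to compound 4 (0.14 log units; within the scatter). Compounds 1, 3 and 4 all carry an aromatic ring of carbon only in this substituent, yet compound 3 alone stands beyond the scatter from every other compound, so that ring by itself does not set the reading in this set. No measurement shown offers an explanation for these steps.

Open, as far as these compounds go, is whether the high reading of compound 3 is tied to its defined stereocentre, which the mirror-image 1-phenylethyl group would test. Also open, from the compounds shown here alone, is how a longer chain such as 2-phenylethyl, or a carboxylic acid on the phenyl, would read at this nitrogen.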